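The compounds below may be only part of what the source reports. "The series", "measured", "known", "first", "only" and "open" are said of these compounds alone.

Within the data shown here, in an ADME assay for protein binding, using equilibrium dialysis, at pH 7.4, tested at 2 uM (on this read-out lower numbers stand for a smaller free fraction and higher numbers for a larger free fraction), compound 2 `CC(C)N(C(=O)[C@H]1CC[C@@H]2C[C@@H]2CC1)c1cc(C#CC(C)(C)C)sc1C(=O)O` gives 0.08, the second highest of the three numbers measured so far. Compound 1 `C[C@@H](CCOc1cccnc1)N(c1cc(C#CC(C)(C)C)sc1C(=O)O)C(=O)[C@H]1CC[C@H](C)CC1` gives 0.02, and compound 3 `CC(C)(C)C#Cc1cc(N(C(=O)[C@H]2CC[C@H](C)CC2)[C@H]2CC[C@H](O)CC2)c(C(=O)O)s1` gives 0.19. Among the measured compounds shown here, the one change measured between neighbours, a 9.5-fold higher number from compound 1 to compound 3 (0.98 log units; beyond the scatter), concerns the group on the amide-type nitrogen. Compound 4 `CC(C)N(c1cc(C#CC(C)(C)C)sc1C(=O)O)C(=O)[C@H]1CC[C@H](CF)CC1` differs from compound 2 elsewhere: a group of 8 heavy atoms (7 carbon, 1 fluorine; one six-membered non-aromatic ring of carbon only) in place of a group of 8 heavy atoms (8 carbon; one three-membered non-aromatic ring of carbon only, one seven-membered non-aromatic ring of carbon only), on a carbonyl carbon. No measured step alters the group on the carbonyl carbon, so nothing among these compounds shows how such a swap moves the number in this assay. The expectation is therefore a step of no change at the digits printed from compound 2 to compound 4 (within the scatter), no larger than the usual scatter. Compound 4 is thus estimated at 0.08, within a range of 0.04 to 0.16.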

Compound 4, unbound fraction: 0.18
Compound 4: middle estimate off by 2.3-fold (0.35 log units), on the low side; measured number outside the range, above it.
By their numbers in this assay, from the lowest: compound 1; then compound 2; then compounds 4 and 3 (each within the scatter of the next).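

On the carbonyl carbon, 4-(fluoromethyl)cyclohexyl in place of the ring-fused group gives a 2.3-fold higher number from compound 2 to compound 4 (0.35 log units; beyond the scatter) in this assay. Among these compounds, this is the first sign that this position, and not only the group on the amide-type nitrogen, can shift the free fraction. Nothing available accounts for the shift.

Going by these compounds, the ring and the fluorine change together, so their shares stay unknown: 4-methylcyclohexyl appears only in compound 1 and compound 3, which carry other groups on the amide-type nitrogen. On these data alone, how a hydroxymethyl or amine on that ring would behave also remains open.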